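The compounds below may be only part of what the source reports. "The series", "measured", "known", "first", "only" and "open" are said of these compounds alone.

Measured in a functional assay on A549 cells (Homo sapiens) for antiproliferative activity, read by MTT assay, with a stated time of 48 h; a higher number here means a weaker inhibitor, a lower number a stronger inhibitor:
- compound 1 `COc1ccc2c(/C=C/C(=O)c3cc(OC)c(OC)c(SC)c3)c[nH]c2c1` gives 115 nM
- compound 2 `COc1ccc2c(/C=C/C(=O)c3cc(OC)c(OC)c([N+](=O)[O-])c3)c[nH]c2c1` gives 331 nM
- compound 3 `COc1ccc2c(/C=C/C(=O)c3cc(OC)c(OC)c(SC)c3)cn(C)c2c1` gives 156 nM

Compound 3, at 156 nM, cannot be told apart from compound 1, given a 1.4-fold higher number from compound 1 to compound 3 (0.13 log units; within the scatter), and both lie under compound 2, at 331 nM. Compound 4 `COc1ccc2c(/C=C/C(=O)c3cc(OC)c(OC)c([N+](=O)[O-])c3)cn(C)c2c1` carries nitro in place of methylsulfanyl on an aromatic carbon, ortho to a methoxy group: nitro in place of methylsulfanyl on an aromatic carbon. Among the measured compounds shown here, only one measured step makes the same swap, a 2.9-fold higher number from compound 1 to compound 2 (0.46 log units; beyond the scatter), on compounds with hydrogen rather than methyl on the aromatic nitrogen. That single pair points to a similar rise in this assay, towards a weaker inhibitor. The expected step is a 2.8-fold higher number from compound 3 to compound 4 (0.45 log units; beyond the scatter). For compound 4 the estimate is 440 nM, with an expected range of 220 nM to 880 nM.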

Compound 4, half-maximal inhibitory concentration: 1020 nM
Beside the measured number, compound 4's estimate is 2.3-fold (0.37 log units) below it, and the stated range ends below it.
By their numbers in this assay, from the lowest: compounds 1 and 3 (each within the scatter of the next); then compound 2; then compound 4.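

Across this assay, nitro in place of methylsulfanyl on this aromatic carbon now gives a weaker inhibitor on both cores, the new case being a 6.5-fold higher number from compound 3 to compound 4 (0.82 log units; beyond the scatter), so the loss no longer rests on one pair: the same change on two cores in this assay, a 2.9-fold higher number (0.46 log units; beyond the scatter) from compound 1 to compound 2 and a 6.5-fold higher number (0.82 log units; beyond the scatter) from compound 3 to compound 4, 2.3-fold (0.36 log units) apart, within the scatter of two such steps. Methyl on the aromatic nitrogen, unreadable with methylsulfanyl present, now shows a loss with nitro present, a 3.1-fold higher number from compound 2 to compound 4 (0.49 log units; beyond the scatter). That contrast is not firm, though: the same change on two cores in this assay, a 1.4-fold higher number (0.13 log units; within the scatter) from compound 1 to compound 3 and a 3.1-fold higher number (0.49 log units; beyond the scatter) from compound 2 to compound 4, 2.3-fold (0.36 log units) apart, within the scatter of two such steps.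

Only methylsulfanyl and nitro are shown at this position, so how an amine or a carboxylic acid there would behave stays open. Also open, as far as these compounds go, is what an ethyl group or longer chain would do on the aromatic nitrogen.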